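Swapping a phenoxy for a dimethylamino on an aryl pyrazole

A few compounds are considered here, and "the series" means these few. Any claim that something is new, unique, unknown or untested is made for them only; others in the source may bear on it.

Measured compounds:
compound 1, `COc1cc(C)cc(-c2c(-c3ccnc(-c4ccc(C(C)=O)cc4)c3)cnn2CC#N)c1`, > 100000 nM
compound 2, `Cc1cc(O)cc(-c2nn(CC#N)cc2-c2ccnc(-c3ccc(Oc4ccccc4)cc3)c2)c1`, 26100 nM

Two compounds share a core and were tested in a functional assay on DU-145 cells (Homo sapiens) for inhibition, read by sulforhodamine B assay, with a stated time of 48 h; on this read-out higher numbers stand for lower toxicity in this test and lower numbers for higher toxicity in this test. Compound 1 returns only > 100000 nM, which is a limit of the assay and not a number; (the limit of > 100000 nM in this assay, at which 1 of the 2 values shown sits). Among the measured compounds shown here, compound 2 is the only one with a measured number, giving 26100 nM in this assay. Compound 3, `Cc1cc(O)cc(-c2nn(CC#N)cc2-c2ccnc(-c3ccc(N(C)C)cc3)c2)c1`, has not been measured yet. It differs from compound 2 in one place: dimethylamino in place of phenoxy on an aromatic carbon. For the measured compounds named here, with no measured pair showing a change of this kind, there is no direct guide to the size or direction of the effect. The expectation is therefore a step of a 1.1-fold higher number from compound 2 to compound 3 (0.06 log units; within the scatter), within the usual scatter of repeated measurements. Compound 3 is estimated to give 30000 nM, expected to fall between 9000 nM and 100000 nM.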

Compound 3, concentration lethal to 50% of the cells: 53200 nM
Compound 3: the middle estimate sits 1.8-fold (0.25 log units) below what was measured, within the range that was stated.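

In this assay, replacing phenoxy with dimethylamino on this aromatic carbon gives a 2.0-fold higher number from compound 2 to compound 3 (0.31 log units; beyond the scatter). Among the compounds shown here, this is the first measured step at this position, and it shows that the group here, para to a large group, has a modest effect on the read-out, moving it towards lower toxicity in this test. The range left for further upward steps is also bounded: the limit of > 100000 nM in this assay, at which 1 of the 3 values shown sits.

This single swap removes a ring and brings in a nitrogen at once, so the compounds shown cannot separate what each of those two changes contributes. Going by these compounds, what a primary amine or a carboxylic acid would do at this position remains open, as does whether the same swap would give a similar step on a different core.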